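Inverting one stereocentre of compound 3

The compounds below may be only part of what the source reports. "The series", "measured", "known", "first", "only" and "open" are said of these compounds alone.

- Compound 1 `Cc1cc(=O)c2c(OCC3CO3)cc(OCC3CO3)cc2o1`: 7300 nM
- Compound 2 `Cc1cc(=O)c2c(O)cc(OC[C@H]3CO3)cc2o1`: 15200 nM
- Compound 3 `Cc1cc(=O)c2c(OC[C@@H]3CO3)cc(OC[C@@H]3CO3)cc2o1`: 24500 nM

All three values come from a functional assay on DU-145 cells (Homo sapiens) for antiproliferative activity, with a stated time of 48 h; a higher number here means a weaker inhibitor, a lower number a stronger inhibitor. Compound 3 and compound 2 lie within the scatter of each other, while compound 1 stands clearly apart from compound 3. Compound 4 `Cc1cc(=O)c2c(OC[C@@H]3CO3)cc(OC[C@H]3CO3)cc2o1` has not yet been measured. It keeps every atom and bond of compound 3, and only the drawn configuration changes: the two compounds have the same atoms and bonds and differ only in configuration as drawn: 1 of 2 stereo elements differ; a stereocentre at a saturated ring carbon is drawn S in compound 3 and R in compound 4.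

Within the data shown here, the one measured step that bears on this is a 3.4-fold higher number from compound 1 to compound 3 (0.53 log units; beyond the scatter). That modest step goes with the fact that one of compounds 1 and 3 is drawn with a defined configuration and the other without, at the place where they differ, so configuration is the only difference on record there. Compound 1 is drawn without configuration. If it contains other arrangements of these centres, some of them may well have lower numbers than compound 3, so a modest step towards a lower number is expected in this assay, though it may stay small.

For compound 4 the estimated value is 11000 nM, with an expected range of 4500 nM to 26000 nM. This estimate means an expected 2.2-fold lower number from compound 3 to compound 4 (0.35 log units; beyond the scatter).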

Compound 4, half-maximal inhibitory concentration: 20400 nM
Beside the measured number, compound 4's estimate is 1.9-fold (0.27 log units) below it, within the range that was stated.
By their numbers in this assay, from the lowest: compound 1; then compounds 2, 4 and 3 (each within the scatter of the next).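

In this assay, inverting this one stereocentre gives a 1.2-fold lower number from compound 3 to compound 4 (0.08 log units; within the scatter), so the change from S to R has no readable effect at this position: the fact that compounds 3 and 4 differ only in the configuration as drawn. Compound 1, drawn without configuration, still stands apart from this second defined form, with a 2.8-fold higher number from compound 1 to compound 4 (0.45 log units; beyond the scatter), so the gap seen for compound 3 is not confined to a single drawn arrangement: the fact that one of compounds 1 and 4 is drawn with a defined configuration and the other without, at the place where they differ. Placing (oxiran-2-yl)methyl in place of hydrogen on an oxygen on an aromatic ring gives a 1.3-fold higher number from compound 2 to compound 4 (0.13 log units; within the scatter), so this added group brings no readable shift here.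

It remains open which arrangement of the two centres, if any, lies behind the lower number of compound 1. Also open, on these data alone, is how an amine or a carboxylic acid in place of (oxiran-2-yl)methyl would read in this assay.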